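This account rests on a few compounds, and the source may have more. Where it says the series, first, only, none or still open, it means among the compounds named here.

Of the compounds shown here, two that share one core have been measured in a functional assay on HepG2 cells (Homo sapiens) for inhibition, read by MTT assay, with a stated time of 48 h; a lower number here means a stronger inhibitor, a higher number a weaker inhibitor. Compound 1 `CCOC(=O)C1=C(NN=C(C(C)=O)C(C)=O)Nc2[nH]nc(C)c2C1c1ccc(N(C)C)cc1` gives 8480 nM and compound 2 `CCOC(=O)C1=C(N/N=C(/Br)c2ccccc2)Nc2[nH]nc(C)c2C1c1ccc(N(C)C)cc1` gives 72000 nM, which makes compound 2 the weaker inhibitor of the pair. The two differ only in the group on an amine nitrogen, and the measured change there, an 8.5-fold higher number from compound 1 to compound 2 (0.93 log units; beyond the scatter), is modest but beyond the scatter.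

Compound 3 `CCOC(=O)C1=C(N/N=C(/C(=O)Br)c2ccc(Cl)cc2)Nc2[nH]nc(C)c2C1c1ccc(N(C)C)cc1` alters that same group again: a group of 12 heavy atoms (8 carbon, 1 nitrogen, 1 oxygen, 1 chlorine, 1 bromine; one six-membered aromatic ring of carbon only) in place of a group of 9 heavy atoms (7 carbon, 1 nitrogen, 1 bromine; one six-membered aromatic ring of carbon only), on an amine nitrogen. The new group keeps the six-membered aromatic ring of carbon only and the bromine of compound 2. It also carries oxygen, as the group of compound 1 does, and chlorine, which neither measured group has. For the measured compounds named here, no measured step shows what the chlorine does.

Going by the values given here, the single guide to how far a change at this place can move the number is an 8.5-fold higher number from compound 1 to compound 2 (0.93 log units; beyond the scatter), and the oxygen-bearing group of compound 1 stands at 8480 nM. A smaller move towards a lower number is therefore expected in this assay, estimated as a 2.4-fold lower number from compound 2 to compound 3 (0.38 log units; beyond the scatter). Compound 3 is estimated at 30000 nM, with an expected range from 8000 nM to 110000 nM.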

Compound 3, half-maximal inhibitory concentration: 50300 nM
Estimate against measurement, compound 3: 1.7-fold (0.22 log units) below; the range from low to high includes it.
By their numbers in this assay, from the lowest: compound 1; then compounds 3 and 2 (each within the scatter of the next).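

In this assay, the step to the larger group gives a 1.4-fold lower number from compound 2 to compound 3 (0.16 log units; within the scatter), so adding oxygen and chlorine to the group that already holds the carbon-only aromatic ring and the bromine leaves compound 2 and compound 3 indistinguishable. The other comparison gives a 5.9-fold higher number from compound 1 to compound 3 (0.77 log units; beyond the scatter), which means that compound 1, whose group has no ring, now stands apart from both ring-bearing compounds, and that oxygen in the group is not enough on its own to bring the number down to that of compound 1. Nothing measured here explains either result.

The oxygen and chlorine enter together in compound 3, and no compound shown pairs the ring and bromine of compound 2 with only one of them, so their separate contributions, which might even offset each other, cannot be read. Going by these compounds, it also remains open whether the lower number of compound 1 depends on the absence of a ring, something a ring-free group with a longer carbon chain could test, or whether a carboxylic acid or an amine on the ring would move the number at this position.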